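Removing the hydroxyethyl chain from a weak inhibitor

The source may report more compounds than this note shows. Statements on the series, on what has been measured and on what is new or still open speak of the compounds shown alone.

Compound 2 `OCCc1cc2nn(-c3ccccc3)cc2cn1` sits at the edge of what a functional assay on MCF7 cells (Homo sapiens) for inhibition, read by fluorescence, with a stated time of 72 h (a higher number here means a weaker inhibitor of growth, a lower number a stronger inhibitor of growth), can report: in this assay compound 2 gives > 100000 nM, a limit of the assay and not a number. For comparison, compound 1 `CC(C)c1nccc2nn(-c3ccccc3)cc12` in this assay gives 98800 nM. Within the data shown here, the only evidence on the measured compounds is the limit of > 100000 nM in this assay, at which 1 of the 2 values shown sits. Compound 3 `c1ccc(-n2cc3cnccc3n2)cc1` differs from compound 2 by hydrogen in place of 2-hydroxyethyl on an aromatic carbon. Among the measured compounds shown here, no measured step covers this change, so the writer expects a number no higher from compound 2 to compound 3 (the limit leaves the size open) to be a step no larger than the scatter. Compound 3 is therefore estimated at 100000 nM, within 30000 nM to 300000 nM.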

Compound 3, concentration for 50% growth inhibition: > 100000 nM
Compound 3 gave a limit, no number; the forecaster's own chance of this, stated with the estimate: 60%; the middle value lies on the limit itself.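

With hydrogen in place of 2-hydroxyethyl, compound 3 gives only a limit in this assay, as compound 2 does, so the step between these two cannot be read. Among these compounds, the one step that can be read is an at least 1.0-fold higher number from compound 1 to compound 3 (0.00 log units; that floor lies within the scatter), with hydrogen in place of isopropyl on an aromatic carbon. Removing either chain therefore brings no readable gain, and the results stay at the edge of the assay: the limit of > 100000 nM in this assay, at which 2 of the 3 values shown sit.

From the compounds shown here alone, whether an amine or a carboxylic acid on this aromatic carbon would give a number within the range of this assay stays open. The same holds for a longer chain.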